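A few compounds are considered here, and "the series" means these few. Any claim that something is new, unique, unknown or untested is made for them only; others in the source may bear on it.

Compound 2 `Clc1cccc(Nc2ccc(N3CC4CC(C3)N4)cn2)c1` carries a 3-chlorophenyl group on a nitrogen attached to the shared core. Among the compounds with values here, in an assay on cell membranes for displacement of a labelled ligand from Neuronal acetylcholine receptor; alpha4/beta2 (Rattus norvegicus) (a lower number here means a stronger inhibitor, a higher number a weaker inhibitor), compound 2 gives 2.2 nM, the lower of the two numbers measured so far. Within the data shown here, its only neighbour is compound 1 `Clc1ccc(Nc2ccc(N3CC4CC(C3)N4)cn2)cc1`, in which the chlorine sits as a 4-chlorophenyl group; in this assay compound 1 gives 2.49 nM. The step from these two is a 1.1-fold lower number from compound 1 to compound 2 (0.05 log units; within the scatter), so moving the chlorine around the ring left the number where it was, within the scatter of the measurement.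

Compound 3 `Clc1ccc(Nc2ccc(N3CC4CC(C3)N4)cn2)cc1Cl` is not yet measured. It differs from compound 2 by chloro in place of hydrogen on an aromatic carbon, so the aromatic ring now carries two chlorine atoms. Among the measured compounds shown here, the one measured step bearing on this change, a 1.1-fold lower number from compound 1 to compound 2 (0.05 log units; within the scatter), shows that the position of a single chlorine on this ring made no difference beyond the scatter. Nothing measured tells how a second chlorine acts. The expectation is therefore a step of about a 1.1-fold higher number from compound 2 to compound 3 (0.06 log units; within the scatter), that is no change beyond the scatter, with a wide margin for the unknown. Compound 3 is thus estimated at 2.5 nM, in the range 0.8 nM to 8 nM.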

Compound 3, inhibition constant: 2.3 nM
Compound 3: the middle estimate sits 1.1-fold (0.04 log units) above what was measured, within the range that was stated.
By their numbers in this assay, from the lowest: compounds 2, 3 and 1 (each within the scatter of the next).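

A second chlorine on this ring makes no difference beyond the scatter in this assay. This holds whether the comparison starts from the 3-chlorophenyl compound (a 1.0-fold higher number from compound 2 to compound 3 (0.02 log units; within the scatter)) or from the 4-chlorophenyl compound (a 1.1-fold lower number from compound 1 to compound 3 (0.03 log units; within the scatter)). The earlier pair showed only that a single chlorine could sit at either of two places on the ring with the numbers staying within the scatter of each other, whereas compound 3 shows that the same holds with both places filled, the new chlorine standing ortho to a chloro group and para to a large group. No measurement is available that would explain why the added atom leaves the number where it is.

All three compounds shown carry only chlorine on this ring, so the ring with no chlorine at all remains an open comparison, and without it the contribution of the chlorine itself cannot be judged. From the compounds shown here alone, it also remains open whether a different group at this position, such as a methoxy group, an amine or a carboxylic acid, would stay within the scatter as chlorine does.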